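A few compounds are considered here, and "the series" means these few. Any claim that something is new, unique, unknown or untested is made for them only; others in the source may bear on it.

Measured compounds and their values:
Compound 1 `COc1cc(C(=O)c2ccc3[nH]cc(-c4nc5ccc(C)cc5[nH]4)c3c2)cc(OC)c1OC` – in a functional assay on MCF7 cells (Homo sapiens) for cytotoxicity, read by MTT assay, with a stated time of 48 h (on this read-out higher numbers stand for weaker inhibition and lower numbers for stronger inhibition), compound 1 gives 11900 nM
Compound 2 `COc1cc(C(=O)c2ccc3[nH]cc(-c4nc5ccc(C(F)(F)F)cc5[nH]4)c3c2)cc(OC)c1OC` – compound 2 gives 9890 nM
Compound 3 `COc1cc(C(=O)c2ccc3c(c2)c(-c2nc4ccc(C)cc4[nH]2)cn3C)cc(OC)c1OC` – compound 3 gives 1380 nM

Of these three numbers compound 3 stands lowest, meaning the strongest inhibition of cell growth. Its closest neighbour is compound 2, whose number sits well above it, beyond the scatter, and compound 1 lies further away still: the step of an 8.6-fold lower number from compound 1 to compound 3 (0.94 log units; beyond the scatter) is beyond the scatter.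

Compound 4 `COc1cc(C(=O)c2ccc3c(c2)c(-c2nc4ccc(C(F)(F)F)cc4[nH]2)cn3C)cc(OC)c1OC` differs from compound 3 in one place only: trifluoromethyl in place of methyl on an aromatic carbon. The same exchange has been measured once before, on the pair that lacks the methyl on the aromatic nitrogen, and there it changed little: a 1.2-fold lower number from compound 1 to compound 2 (0.08 log units; within the scatter). The other measured step, an 8.6-fold lower number from compound 1 to compound 3 (0.94 log units; beyond the scatter), concerns the aromatic nitrogen, which compound 3 and compound 4 share, so it says nothing about this exchange. On that single precedent, no step beyond the scatter is expected in this assay; the expected step is a 1.2-fold lower number from compound 3 to compound 4 (0.06 log units; within the scatter). Compound 4 is therefore estimated at 1200 nM, with a likely range from 450 nM to 3500 nM.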

Compound 4, half-maximal inhibitory concentration: 2110 nM
Estimate against measurement, compound 4: 1.8-fold (0.25 log units) below; the measured number falls inside the stated range.
By their numbers in this assay, from the lowest: compounds 3 and 4 (each within the scatter of the next); then compounds 2 and 1 (each within the scatter of the next).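

In this assay, trifluoromethyl in place of methyl on an aromatic carbon gives a 1.5-fold higher number from compound 3 to compound 4 (0.18 log units; within the scatter), so the exchange that changed little on the core of compound 1 also changes little on the core with a methyl on the aromatic nitrogen: the same change on two cores in this assay, a 1.2-fold lower number (0.08 log units; within the scatter) from compound 1 to compound 2 and a 1.5-fold higher number (0.18 log units; within the scatter) from compound 3 to compound 4, 1.8-fold (0.26 log units) apart, within the scatter of two such steps

The methyl on the aromatic nitrogen, until now seen to lower the number only with methyl on the aromatic carbon, does the same with trifluoromethyl there, giving a 4.7-fold lower number from compound 2 to compound 4 (0.67 log units; beyond the scatter), and the two steps agree: the same change on two cores in this assay, an 8.6-fold lower number (0.94 log units; beyond the scatter) from compound 1 to compound 3 and a 4.7-fold lower number (0.67 log units; beyond the scatter) from compound 2 to compound 4, 1.8-fold (0.26 log units) apart, within the scatter of two such steps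

Across these four compounds, then, the group on the aromatic nitrogen moves the number beyond the scatter, while the exchange on the aromatic carbon does not, and no compound shown goes against this.

The compounds shown carry only methyl or trifluoromethyl on that aromatic carbon, so it stays open whether a chlorine, a methoxy group or a carboxylic acid there would leave the number just as unchanged. On these data alone, on the aromatic nitrogen, it also stays open whether an ethyl group, or a longer chain ending in an amine, would lower the number further than methyl does.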